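A few compounds are considered here, and "the series" means these few. Any claim that something is new, unique, unknown or untested is made for them only; others in the source may bear on it.

Of the compounds shown here, three sharing one core have been tested in an ADME assay on cells (Splenocyte, Mus musculus, strain BALB/c) for cytotoxicity, read by thymidine incorporation, with a stated time of 24 h; on this read-out lower numbers stand for stronger inhibition and higher numbers for weaker inhibition. Compound 1 `O=C(CCN1CCN(c2ccnc3cc(Cl)ccc23)CC1)N/N=C/c1ccccc1` gives 300 nM. Compound 2 `COc1cc(/C=N/NC(=O)CCN2CCN(c3ccnc4cc(Cl)ccc34)CC2)ccc1OC(C)=O` gives 15800 nM, and compound 3 `O=C(CCN1CCN(c2ccnc3cc(Cl)ccc23)CC1)N/N=C/c1ccccc1Cl` gives 10800 nM. Compound 2 therefore carries the highest number of the three: the gap to compound 1 is large, a 53-fold higher number from compound 1 to compound 2 (1.72 log units; beyond the scatter), whereas the gap to compound 3, a 1.5-fold lower number from compound 2 to compound 3 (0.17 log units; within the scatter), is within the scatter and so does not separate them.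

Compound 4 `O=C(CCN1CCN(c2ccnc3cc(Cl)ccc23)CC1)N/N=C/c1ccccc1O` differs from compound 2 in one place: 2-hydroxyphenyl in place of 4-acetoxy-3-methoxyphenyl on a carbon with a double bond to nitrogen. Going by the values given here, no measured step makes this exact change, so the nearest guides are the two steps away from the unsubstituted phenyl of compound 1, a 53-fold higher number from compound 1 to compound 2 (1.72 log units; beyond the scatter) and a 36-fold higher number from compound 1 to compound 3 (1.56 log units; beyond the scatter), both of which were large and pointed toward higher numbers, and the step of a 1.5-fold lower number from compound 2 to compound 3 (0.17 log units; within the scatter), which shows that the two substituted phenyls sit close together. Compound 4 keeps a substituted phenyl, so a number nearer to compound 2 and compound 3 than to compound 1 seems likely, although the single hydroxyl is a smaller addition and a return part of the way toward compound 1 cannot be ruled out. For compound 4 the expected value in this assay is 5000 nM, within a range of 700 nM to 30000 nM. That estimate means an expected step of a 3.2-fold lower number from compound 2 to compound 4 (0.50 log units; beyond the scatter), with wide uncertainty.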

Compound 4, half-maximal inhibitory concentration: 11500 nM
For compound 4 the middle estimate is 2.3-fold (0.36 log units) below the measured one, within the range that was stated.
By their numbers in this assay, from the lowest: compound 1; then compounds 3, 4 and 2 (each within the scatter of the next).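

In this assay, a single hydroxy on the phenyl is enough to give a 38-fold higher number from compound 1 to compound 4 (1.58 log units; beyond the scatter), so the large step seen earlier with chloro and with 4-acetoxy-3-methoxyphenyl also appears with a much smaller addition. The substituted compounds stay together: a 1.1-fold higher number from compound 3 to compound 4 (0.03 log units; within the scatter) and a 1.4-fold lower number from compound 2 to compound 4 (0.14 log units; within the scatter) both lie within the scatter, even though 2-hydroxyphenyl has fewer heavy atoms than 4-acetoxy-3-methoxyphenyl, so among compound 2, compound 3 and compound 4 neither the size of the group nor the exchange of chloro for hydroxy separates the numbers, and only the unsubstituted phenyl of compound 1 stands apart. No supporting data are available on what lies behind this shared step.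

The compounds shown leave open whether an amine or a carboxylic acid on this phenyl would fall with compound 2, compound 3 and compound 4 or closer to compound 1. They also leave open whether a hydroxy on a different ring carbon, or a group as simple as methyl, would produce the same large step.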